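Swapping the aryl on the ring nitrogen for a thiazolylmethyl

The compounds below may be only part of what the source reports. "The series", "measured", "known", "first", "only" and "open" are said of these compounds alone.

Compound 1 `COc1ccc(-n2nc(Nc3cc(C)[nH]n3)c3ccccc3c2=O)cc1` gives 700 nM in a functional assay on HCT-116 cells (Homo sapiens) for cytotoxicity, read by CellTiter-Glo, with a stated time of 5 days (on this read-out higher numbers stand for weaker inhibition and lower numbers for stronger inhibition), the lowest of the three numbers recorded; compound 3 `Cc1cc(Nc2nn(-c3ccc(F)cc3)c(=O)c3ccccc23)n[nH]1` gives 800 nM, and compound 2 `Cc1cc(Nc2nn(Cc3cccnc3)c(=O)c3ccccc23)n[nH]1` gives 2900 nM. Compound 1 and compound 3 lie within the scatter of each other, as a 1.1-fold higher number from compound 1 to compound 3 (0.06 log units; within the scatter) shows, whereas a 4.1-fold higher number from compound 1 to compound 2 (0.62 log units; beyond the scatter) and a 3.6-fold lower number from compound 2 to compound 3 (0.56 log units; beyond the scatter) both fall beyond it.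

Compound 4 `Cc1cc(Nc2nn(Cc3csc(C)n3)c(=O)c3ccccc23)n[nH]1` has not yet been measured. It differs from compound 1 in one place: (2-methyl-1,3-thiazol-4-yl)methyl in place of 4-methoxyphenyl on an aromatic nitrogen. The step that bears most directly on this change is a 4.1-fold higher number from compound 1 to compound 2 (0.62 log units; beyond the scatter), where a benzylic-type group replaced an aryl group on the same aromatic nitrogen, and its mirror a 3.6-fold lower number from compound 2 to compound 3 (0.56 log units; beyond the scatter). On that basis a modest loss is expected for compound 4, with a 3.6-fold higher number from compound 1 to compound 4 (0.55 log units; beyond the scatter) in this assay. The estimate for compound 4 is therefore 2500 nM, within a range from 900 nM to 7000 nM.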

Compound 4, half-maximal inhibitory concentration: 4180 nM
Estimate against measurement, compound 4: 1.7-fold (0.22 log units) below; measured number inside the range.
By their numbers in this assay, from the lowest: compounds 1 and 3 (each within the scatter of the next); then compounds 2 and 4 (each within the scatter of the next).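

In this assay, a second group joined through a saturated chain carbon on the aromatic nitrogen gives the same kind of rise as the first, with a 6.0-fold higher number from compound 1 to compound 4 (0.78 log units; beyond the scatter) and a 5.2-fold higher number from compound 3 to compound 4 (0.72 log units; beyond the scatter), so among these four compounds both such groups sit on the higher side of both directly attached aryl groups. The ring on that chain carbon matters little here, as a 1.4-fold higher number from compound 2 to compound 4 (0.16 log units; within the scatter) shows that 2-methyl-1,3-thiazol-4-yl and pyridin-3-yl cannot be told apart. Nothing given here explains the rise.

The compounds shown leave open whether the rise follows the chain carbon or the change away from a phenyl ring. A plain benzyl group, or a 2-methyl-1,3-thiazol-4-yl bound directly to the aromatic nitrogen, would separate the two.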